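The compounds below may be only part of what the source reports. "The series", "measured", "known", "first", "only" and "open" are said of these compounds alone.

Compound 2, with the structure `COc1cc(-c2cc(/C=C/C(=O)c3ccc(Cl)c(Cl)c3)[nH]n2)cc(OC)c1OC`, belongs to a small set of compounds that share one core. In a functional assay on 786-0 cells (Homo sapiens) for cytotoxicity, read by sulforhodamine B assay, with a stated time of 48 h, tested at 0.1 uM (a lower number here means a stronger effect, a higher number a weaker effect of the compound at the concentration tested), compound 2 gives 94%, a reading that sits level with its nearest relative, compound 1, whose structure is `COc1cc(-c2cc(/C=C/C(=O)c3ccc(N)cc3)[nH]n2)cc(OC)c1OC` and which gives 94% in this assay. Within the data shown here, the single step already measured, no change at the digits printed from compound 1 to compound 2 (within the scatter), swapped one group on the carbonyl carbon and left the reading where it was.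

Compound 3, with the structure `COc1cc(-c2cc(/C=C/C(=O)c3ccc(F)c(F)c3)[nH]n2)cc(OC)c1OC`, has not been measured. It differs from compound 2 in one place: 3,4-difluorophenyl in place of 3,4-dichlorophenyl on a carbonyl carbon. Among the measured compounds shown here, the only step that bears on this change is the one from compound 1 to compound 2, which changed nothing within the scatter, and that step already exchanged one group on the same carbonyl carbon for another. The expected step in this assay, no change at the digits printed from compound 2 to compound 3 (within the scatter), is therefore none beyond the scatter. Compound 3 is estimated to give 94%, with a range from 84% to 100%.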

Compound 3, a percentage reported as activity, at one concentration (the size of the read-out at that concentration, not a potency): 95%
Estimate against measurement, compound 3: 1 percentage points below; measured number inside the range.
By their numbers in this assay, from the lowest: compounds 1, 2 and 3 (each within the scatter of the next).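

In this assay, exchanging 3,4-dichlorophenyl for 3,4-difluorophenyl on the carbonyl carbon gives a number 1 percentage points higher from compound 2 to compound 3 (within the scatter), so swapping one halogen for another on this ring leaves the reading in place. Comparing this ring with the 4-aminophenyl group gives a number 1 percentage points higher from compound 1 to compound 3 (within the scatter), which means that three different aromatic groups on this carbonyl carbon, with chlorine, fluorine or an amine on the ring, now read alike at this one concentration. Nothing available explains why these groups read alike.

Still open, as far as these compounds go, is whether a group of a different kind here, such as a carboxylic acid, an unsubstituted phenyl ring or a longer chain, would move the reading. A single concentration also cannot show whether compounds 1, 2 and 3 would stay level at other concentrations.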